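This account rests on a few compounds, and the source may have more. Where it says the series, first, only, none or still open, it means among the compounds named here.

Measured compounds:
compound 1 `NC1=NC2(CCOCC2)N(OCCCOc2ccccc2Cl)C(N)=N1` gives 88.2% in an assay on isolated protein for inhibition of Dihydrofolate reductase (Homo sapiens), read by spectrophotometry, using NADPH, with stated times of 5 s and 6 min, tested at 50 uM; a higher number here means a stronger effect of the compound at the concentration tested, a lower number a weaker effect
compound 2 `NC1=NC2(CCSCC2)N(OCCCOc2cccc(Cl)c2Cl)C(N)=N1` gives 89.8% in this assay

Compound 2 stands at the higher of the two numbers, but compound 1 lies within the scatter of it, so no order between them can be drawn. Compound 3 `COc1ccc(OCCCON2C(N)=NC(N)=NC23CCSCC3)cc1` is not yet measured. For the measured compounds named here, it differs from compound 2 at one place: 4-methoxyphenyl in place of 2,3-dichlorophenyl on an oxygen on a saturated carbon No measured pair shows this change, so its size is unknown. A modest downward step is expected, a number 9.8 percentage points lower from compound 2 to compound 3 (within the scatter), which may still lie within the scatter. Compound 3 is estimated at 80%, between 62% and 92%.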

Compound 3, a percentage reported as inhibition, at one concentration (the size of the read-out at that concentration, not a potency): 86.6%
Beside the measured number, compound 3's estimate is 6.6 percentage points below it; measured number inside the range.
By their numbers in this assay, from the lowest: compounds 3, 1 and 2 (each within the scatter of the next).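

At the place on an oxygen on a saturated carbon, 4-methoxyphenyl in place of 2,3-dichlorophenyl gives a number 3.2 percentage points lower from compound 2 to compound 3 (within the scatter) in this assay. For the compounds shown here, this is the first single change that can be read, and it stays within the scatter. Among the compounds shown, an aryl group without chlorine therefore reads the same as the 2,3-dichlorophenyl group, and no measurement bears on why.

Open, as far as these compounds go, is whether an amine or a carboxylic acid on this phenyl ring would shift the read-out. A longer chain to the ring is also untested among these compounds.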